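The compounds below may be only part of what the source reports. "The series", "measured", "known", "first", "only" and "open" are said of these compounds alone.

Measured compounds:
compound 1 `O=C(Nc1nc2ccc(Cl)cc2s1)c1cn(-c2ccccc2)nc1-c1ccccc1`: 7810 nM
compound 2 `O=C(Nc1nc2ccc(Cl)cc2s1)c1cn(-c2ccccc2)nc1-c1ccc(F)cc1`: 3320 nM
compound 3 `COc1ccc(-c2nn(-c3ccccc3)cc2C(=O)Nc2nc3ccc(F)cc3s2)cc1`: 5560 nM

All three were tested in a functional assay on HT-29 cells (Homo sapiens) for cytotoxicity, read by MTT assay, with a stated time of 72 h; on this read-out higher numbers stand for weaker inhibition and lower numbers for stronger inhibition. In this assay compound 3 gives 5560 nM, the second highest of the three numbers; its gaps to compound 1 at 7810 nM and to compound 2 at 3320 nM both lie within the scatter, so no order among them is established. Compound 4 `COc1ccc(-c2nn(-c3ccccc3)cc2C(=O)Nc2nc3ccc(Cl)cc3s2)cc1` differs from compound 3 by chloro in place of fluoro on an aromatic carbon. Going by the values given here, the only measured step, a 2.4-fold lower number from compound 1 to compound 2 (0.37 log units; beyond the scatter), concerns a fluoro entering on a different ring and says nothing about swapping one halogen for another on the shared core. Among the compounds with values here, with no bearing step, the change is expected to leave the number within the scatter, as a 1.1-fold lower number from compound 3 to compound 4 (0.05 log units; within the scatter). Compound 4 is therefore estimated at 5000 nM, in the range 2000 nM to 12000 nM.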

Compound 4, half-maximal inhibitory concentration: 6570 nM
Estimate against measurement, compound 4: 1.3-fold (0.12 log units) below, and the stated range covers the measured number.
By their numbers in this assay, from the lowest: compounds 2, 3, 4 and 1 (each within the scatter of the next, the first and the last beyond it).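

In this assay the change from 6-fluoro-1,3-benzothiazol-2-yl to 6-chloro-1,3-benzothiazol-2-yl (a 1.2-fold higher number from compound 3 to compound 4 (0.07 log units; within the scatter)) stays within the scatter, so these two halogens are not told apart at this position. At the other place that varies, methoxy also lies within the scatter of both hydrogen (a 1.2-fold lower number from compound 1 to compound 4 (0.08 log units; within the scatter)) and fluoro (a 2.0-fold higher number from compound 2 to compound 4 (0.30 log units; within the scatter)), although hydrogen and fluoro lie beyond the scatter of each other. No supporting evidence is available to explain these results.

From the compounds shown here alone, whether an amine or a carboxylic acid at either place would shift the number beyond the scatter remains open.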